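The source may hold more compounds than are shown below. What is called first, only, known or untested is meant among the compounds shown, and "the series" means these compounds.

Of the compounds shown here, three of a shared core have been measured in an assay on microsomes from liver for inhibition of 3-hydroxy-3-methylglutaryl-coenzyme A reductase (Rattus norvegicus); a higher number here means a weaker inhibitor, a lower number a stronger inhibitor. Compound 1 `Cc1ccc(CNC(=O)c2nn(-c3ccc(F)cc3)c(CC[C@@H](O)C[C@@H](O)CC(=O)O)c2C(C)C)cc1` gives 2.5 nM, compound 2 `CC(C)c1c(C(=O)N2CCC[C@H](N3CCC4C=CC=CC4C3)C2)nn(-c2ccc(F)cc2)c1CC[C@@H](O)C[C@@H](O)CC(=O)O` gives 10 nM, and compound 3 `COc1ccc(CNC(=O)c2nn(-c3ccc(F)cc3)c(OC[C@@H](O)C[C@@H](O)CC(=O)O)c2C(C)C)cc1` gives 12 nM. Compound 3 thus carries the highest of the three numbers; its gap to compound 2 lies within the usual scatter, while its gap to compound 1 lies beyond it. Compound 4 `CC(C)c1c(C(=O)N(C)[C@H](C)c2ccccc2)nn(-c2ccc(F)cc2)c1OC[C@@H](O)C[C@@H](O)CC(=O)O` has not yet been measured. It differs from compound 3 in one place: methyl(1-phenylethyl)amino in place of (4-methoxybenzyl)amino on a carbonyl carbon. Among the measured compounds shown here, no pair of measured compounds shows this change, so the expectation rests on the values alone. A small step toward a higher number is expected in this assay, a 2.1-fold higher number from compound 3 to compound 4 (0.32 log units; beyond the scatter), of a size near the scatter. Compound 4 is therefore estimated at 25 nM, within a range from 8 nM to 80 nM.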

Compound 4, half-maximal inhibitory concentration: 21 nM
Compound 4: middle estimate off by 1.2-fold (0.08 log units), on the high side; the measured number falls inside the stated range.
By their numbers in this assay, from the lowest: compound 1; then compounds 2, 3 and 4 (each within the scatter of the next, the first and the last beyond it).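

In this assay, the step at this carbonyl carbon is a 1.8-fold higher number from compound 3 to compound 4 (0.24 log units; within the scatter), so methyl(1-phenylethyl)amino stands in for (4-methoxybenzyl)amino without a clear change in the number. The entering group has no hydrogen-bond donor where the leaving group has one, so this single pair shows that a donor is not required here for a number of this size. Nothing measured here explains the result. The compounds shown leave open whether the added methyl or the defined stereocentre matters on its own, since neither changes alone. As far as these compounds go, how a smaller group, such as a plain amino group, would read at this place also remains open.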